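A few compounds are considered here, and "the series" means these few. Any claim that something is new, unique, unknown or untested is made for them only; others in the source may bear on it.

Compound 1 `COc1cc(Cl)cc(-c2nn(-c3cccc(NC(=O)c4cc(C(F)(F)F)cc(C(F)(F)F)c4)c3)cc2-c2ccncc2)c1` gives 43.6% in a functional assay on RPMI-8226 cells (Homo sapiens) for inhibition, read by sulforhodamine B assay, with a stated time of 48 h, tested at 10 uM; on this read-out higher numbers stand for a weaker effect at the one concentration tested and lower numbers for a stronger effect. Compound 2 `COc1cc(Cl)cc(-c2nn(-c3cccc(NC(=O)c4ccc(Cl)c(Cl)c4)c3)cc2-c2ccncc2)c1` gives 46%. Compound 3 `COc1cc(Cl)cc(-c2nn(-c3cccc(NC(=O)c4cccc(C(F)(F)F)c4)c3)cc2-c2ccncc2)c1` gives 31.5%.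

Compound 2 gives the highest of the three numbers, so the weakest effect; its gap to compound 1 is within the usual scatter, while compound 3 lies beyond it. Compound 4 `COc1cc(Cl)cc(-c2nn(-c3cccc(NC(=O)Nc4ccc(Cl)c(Cl)c4)c3)cc2-c2ccncc2)c1` differs from compound 2 in one place: (3,4-dichlorophenyl)amino in place of 3,4-dichlorophenyl on a carbonyl carbon. The measured steps, a number 12.1 percentage points lower from compound 1 to compound 3 (beyond the scatter) and a number 14.5 percentage points lower from compound 2 to compound 3 (beyond the scatter), both alter the ring attached to the carbonyl, not the link between carbonyl and ring, so none bears directly on this change. Among the measured compounds shown here, with no comparable step known, compound 4 is expected to stay close to compound 2, a step of a number 1 percentage points lower from compound 2 to compound 4 (within the scatter), within the scatter. Compound 4 is thus estimated at 45%, between 28% and 65%.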

Compound 4, a percentage reported as activity, at one concentration (the size of the read-out at that concentration, not a potency): -4.44%
Compound 4: the middle estimate sits 49.4 percentage points above what was measured; measured number outside the range, below it.
By their numbers in this assay, from the lowest: compound 4; then compound 3; then compounds 1 and 2 (each within the scatter of the next).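

Putting (3,4-dichlorophenyl)amino in place of 3,4-dichlorophenyl on this carbonyl carbon in this assay gives a number 50.4 percentage points lower from compound 2 to compound 4 (beyond the scatter), so changing the link to the ring can matter far more here than the earlier ring swaps did. The same group also compares well with 3-(trifluoromethyl)phenyl, with a number 35.9 percentage points lower from compound 3 to compound 4 (beyond the scatter). No measurement shown explains this shift. Still open, as far as these compounds go, is whether (3-(trifluoromethyl)phenyl)amino would behave likewise on this carbonyl carbon, and whether a longer chain, such as a benzylamino group, would keep the effect.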